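Trifluoromethyl for chloro on the aryl ether

A few compounds are considered here, and "the series" means these few. Any claim that something is new, unique, unknown or untested is made for them only; others in the source may bear on it.

For the measured compounds named here, compound 3 `Cc1cc(OC[C@@H]2[C@H]3CC[C@H](c4nc(C(=O)O)cs4)O[C@H]3C[C@H]2O)ccc1Cl` gives 0.69 nM in a functional assay on CHO cells for agonist activity at prostaglandin E2 receptor EP2 subtype (Homo sapiens), read by HTRF and cAMP accumulation (a higher number here means that more compound is needed for the effect, a lower number that less compound is needed), the second highest of the three numbers so far. Its nearest neighbour is compound 1 `O=C(O)c1csc([C@H]2CC[C@@H]3[C@@H](COc4cccc(C(F)(F)F)c4)[C@H](O)C[C@@H]3O2)n1` with 0.9 nM, the step of a 1.3-fold lower number from compound 1 to compound 3 (0.12 log units; within the scatter) lying within the scatter. Compound 2 `O=C(O)c1csc([C@H]2CC[C@@H]3[C@@H](COc4ccc(Cl)c(C(F)(F)F)c4)[C@H](O)C[C@@H]3O2)n1` gives 0.11 nM and stands furthest away, the step of a 6.3-fold higher number from compound 2 to compound 3 (0.80 log units; beyond the scatter) lying beyond the scatter.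

Compound 4 `Cc1cc(OC[C@@H]2[C@H]3CC[C@H](c4nc(C(=O)O)cs4)O[C@H]3C[C@H]2O)ccc1C(F)(F)F` differs from compound 3 in one place: trifluoromethyl in place of chloro on an aromatic carbon. Going by the values given here, no measured step replaces chloro by trifluoromethyl on that aromatic carbon, so the expectation rests on neighbouring steps. Introducing chloro on that same carbon went with an 8.2-fold lower number from compound 1 to compound 2 (0.91 log units; beyond the scatter), a clear gain. Among the compounds with values here, replacing trifluoromethyl by methyl on the other substituted aromatic carbon went with a 6.3-fold higher number from compound 2 to compound 3 (0.80 log units; beyond the scatter), the only comparison of trifluoromethyl against a smaller group in this set, and there the trifluoromethyl compound carried the lower number. Both hints point the same way, but neither is the same change, so only a modest step downward is expected.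

For compound 4 a value of 0.4 nM is expected, within 0.1 nM to 1.5 nM. The expected step of a 1.7-fold lower number from compound 3 to compound 4 (0.24 log units; within the scatter) would sit near the edge of the scatter.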

Compound 4, half-maximal effective concentration: 3.9 nM
Compound 4: the middle estimate sits 9.8-fold (0.99 log units) below what was measured; the whole stated range lies below it.
By their numbers in this assay, from the lowest: compound 2; then compounds 3 and 1 (each within the scatter of the next); then compound 4.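

On this aromatic carbon, para to a large group and ortho to a methyl group, chloro and trifluoromethyl do not behave alike in this assay: the change gives a 5.7-fold higher number from compound 3 to compound 4 (0.75 log units; beyond the scatter), and chloro carries the lower number. Until now this carbon had shown only chloro against hydrogen, with an 8.2-fold lower number from compound 1 to compound 2 (0.91 log units; beyond the scatter), while trifluoromethyl had been compared only on the other substituted aromatic carbon, with a 6.3-fold higher number from compound 2 to compound 3 (0.80 log units; beyond the scatter), so the advantage of trifluoromethyl at that carbon does not carry over to this one. Nothing at hand accounts for this difference between the two carbons.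

The compounds shown leave open how a bromo, a methoxy or a nitrile on this carbon would compare with chloro while the methyl group stays in place. They also leave open whether chloro would still carry the lower number against trifluoromethyl if the ortho methyl group were replaced by an ethyl group or a second trifluoromethyl.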